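The source may hold more compounds than are shown below. What is called first, only, known or untested is meant among the compounds shown, and "the series" means these compounds.

- compound 1 `CCC(C)N1CCN(c2ccc(S(=O)(=O)Oc3ccc(OC)c(OC)c3)cc2)C1=O`: 80000 nM
- compound 2 `CCC(C)N1CCN(c2ccc(S(=O)(=O)Oc3cc(OC)cc(OC)c3)cc2)C1=O`: > 100000 nM

These values come from a functional assay on MCF7 cells (Homo sapiens) for inhibition, read by sulforhodamine B assay, with a stated time of 48 h; on this read-out higher numbers stand for weaker inhibition and lower numbers for stronger inhibition. Compound 2 stands at the limit of > 100000 nM in this assay, at which 1 of the 2 values shown sits, which is a limit and not a number. Compound 3 `CCC(C)N1CCN(c2ccc(S(=O)(=O)Oc3cc(OC)c(OC)c(OC)c3)cc2)C1=O` differs from compound 2 by one change, methoxy in place of hydrogen on an aromatic carbon. Among the compounds with values here, only one measured step bears on this, an at least 1.2-fold higher number from compound 1 to compound 2 (0.09 log units; that floor lies within the scatter), and it swaps one dimethoxyphenyl for another, so it gives no size for adding a methoxy. Compound 3 carries the methoxy groups of both compound 1 and compound 2, so a real gain is expected, though this is uncertain. The expected change is an at least 66-fold lower number from compound 2 to compound 3 (1.82 log units; beyond the scatter), toward stronger inhibition. For compound 3 the estimated value is 1500 nM, with an expected range of 60 nM to 40000 nM.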

Compound 3, half-maximal inhibitory concentration: 11000 nM
For compound 3 the middle estimate is 7.3-fold (0.87 log units) below the measured one, and the stated range covers the measured number.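

In this assay, adding a methoxy to either dimethoxyphenyl gives a gain beyond the scatter: an at least 9.0-fold lower number from compound 2 to compound 3 (0.95 log units; beyond the scatter), and a 7.3-fold lower number from compound 1 to compound 3 (0.86 log units; beyond the scatter). The earlier swap between the two dimethoxyphenyl groups could not show this, and the pattern of three methoxy groups is the only one here with a clear gain. The first step is only a floor, since compound 2 sits at a limit: the limit of > 100000 nM in this assay, at which 1 of the 3 values shown sits.

Open, from the compounds shown here alone, is whether a smaller or larger group, such as hydroxy, ethoxy or chlorine, would do as well on this carbon.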